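Amide cap variation and tolerance on Vero cells

The source may hold more compounds than are shown below. What is called first, only, known or untested is meant among the compounds shown, and "the series" means these compounds.

Compound 1 `O=C(c1ccc(Cl)cc1)N1CCN(c2nc(=O)c3cc(C(F)(F)F)cc([N+](=O)[O-])c3s2)CC1` carries a (4-chlorophenyl)carbonyl on the amide-type nitrogen in a ring. In an ADME assay on Vero cells (Chlorocebus sabaeus) for cytotoxicity, read by MTT assay, with a stated time of 72 h (a lower number here means that less compound is tolerated, a higher number that more compound is tolerated), compound 1 returns > 125000 nM as a limit only. Compound 2 `Cc1ccc(C(=O)N2CCN(c3nc(=O)c4cc(C(F)(F)F)cc([N+](=O)[O-])c4s3)CC2)cc1` likewise returns > 125000 nM as a limit in this assay. Compound 3 `O=C(C1CCCC1)N1CCN(c2nc(=O)c3cc(C(F)(F)F)cc([N+](=O)[O-])c3s2)CC1` gives 120000 nM in this assay. The steps of an at least 1.0-fold lower number from compound 1 to compound 3 (0.01 log units; that floor lies within the scatter) and an at least 1.0-fold lower number from compound 2 to compound 3 (0.01 log units; that floor lies within the scatter) both stay within the scatter, while a step that the two limits leave unreadable from compound 1 to compound 2 cannot be read, since the limit of > 125000 nM in this assay, at which 2 of the 3 values shown sit, holds both values.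

Compound 4 `CCC(=O)N1CCN(c2nc(=O)c3cc(C(F)(F)F)cc([N+](=O)[O-])c3s2)CC1` differs from compound 1 as ethyl in place of 4-chlorophenyl on a carbonyl carbon shows. The nearest measured comparison is an at least 1.0-fold lower number from compound 1 to compound 3 (0.01 log units; that floor lies within the scatter), where the same 4-chlorophenyl on the carbonyl carbon was also replaced and nothing beyond the scatter followed. No step beyond the scatter is therefore expected, and the estimated step of a number no higher from compound 1 to compound 4 (the limit leaves the size open) reflects that. Compound 4 is expected to give 125000 nM in this assay, within 60000 nM to 250000 nM, most likely reported only as a limit again.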

Compound 4, half-maximal cytotoxic concentration: > 125000 nM
Compound 4: only a limit was reported; the forecaster's own chance of this, stated with the estimate: 70%; the middle value sits exactly at the limit.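

In this assay compound 4, with an ethyl and no ring on the carbonyl carbon, gives > 125000 nM, a limit only. For the compounds shown here, the only readable step is an at least 1.0-fold higher number from compound 3 to compound 4 (0.01 log units; that floor lies within the scatter), and the steps involving the other limits cannot be read. So a plain chain on this carbonyl carbon now joins 4-chlorophenyl, 4-methylphenyl and cyclopentyl with no step shown beyond the scatter, and the values crowd at one ceiling: the limit of > 125000 nM in this assay, at which 3 of the 4 values shown sit.

Going by these compounds, whether an amine, a carboxylic acid or a longer chain on this carbonyl carbon would bring a clearly lower number stays open. On these data alone, the true values behind the limits also remain unknown.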